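Methyl for phenyl on two related dihydropyridine cores

The source may hold more compounds than are shown below. What is called first, only, known or untested is meant among the compounds shown, and "the series" means these compounds.

Measured compounds:
compound 1, `CCOC(=O)C1=C(C)NC(C)=C(C(=O)OC)C1c1ccc(-c2cc(=O)cc(-c3ccccc3)o2)cc1`, 94400 nM
compound 2, `CCOC(=O)C1=C(C)NC(C)=C(C(=O)OC)C1c1ccc(-c2cc(=O)cc(C)o2)cc1`, 86100 nM
compound 3, `CCOC(=O)C1=C(C)NC(C)=C(C(=O)OC)C1c1cc(=O)cc(-c2ccccc2)o1`, 2030 nM

Compound 1 and compound 2 share one core, and compound 3 carries a different one; the difference between the two cores is not broken down here. In an assay on isolated protein (strain albino) for inhibition of Voltage-dependent L-type calcium channel subunit alpha-1C (Cavia porcellus) (a higher number here means a weaker inhibitor, a lower number a stronger inhibitor), compound 1 gives 94400 nM and compound 2 gives 86100 nM. The change between them is methyl in place of phenyl on an aromatic carbon, and it made a 1.1-fold lower number from compound 1 to compound 2 (0.04 log units; within the scatter). Compound 3 stands apart: in this assay compound 3 gives 2030 nM, far from both compounds on the other core.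

Compound 4, `CCOC(=O)C1=C(C)NC(C)=C(C(=O)OC)C1c1cc(=O)cc(C)o1`, is not yet measured. It differs from compound 3 by methyl in place of phenyl on an aromatic carbon, the same change that turned compound 1 into compound 2, made at the same place. Because that change gave a 1.1-fold lower number from compound 1 to compound 2 (0.04 log units; within the scatter), the step from compound 3 to compound 4 is expected to be small as well, about a 1.1-fold lower number from compound 3 to compound 4 (0.03 log units; within the scatter). On that basis compound 4 is estimated at 1900 nM in this assay, with a likely range from 700 nM to 6000 nM, resting on compound 3 alone as the starting point.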

Compound 4, half-maximal inhibitory concentration: 1630 nM
Beside the measured number, compound 4's estimate is 1.2-fold (0.07 log units) above it; measured number inside the range.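

In this assay, methyl in place of phenyl on an aromatic carbon gave a 1.2-fold lower number from compound 3 to compound 4 (0.10 log units; within the scatter), so on the core of compound 3 this change again made no step beyond the scatter, as on the core of compound 1. The two steps agree across the two cores: the same change on two cores in this assay, a 1.1-fold lower number (0.04 log units; within the scatter) from compound 1 to compound 2 and a 1.2-fold lower number (0.10 log units; within the scatter) from compound 3 to compound 4, 1.1-fold (0.06 log units) apart, within the scatter of two such steps. This shows that, for this one pair of groups at this one place and in this one assay, a change that left the number in place on one core also left it in place on the other; it does not show that any other change would carry between these cores, and it says nothing about what separates the cores themselves.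

The compounds shown leave open whether a group other than phenyl or methyl at this place, such as an amine, a carboxylic acid or a longer chain, would also behave alike on both cores. They also leave open whether a larger step on one core would reappear at the same size on the other.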